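Series notes: from compound 3 to compound 4

A few compounds are considered here, and "the series" means these few. Any claim that something is new, unique, unknown or untested is made for them only; others in the source may bear on it.

Three compounds of the series have numbers in a functional assay on U-87MG ATCC cells for antiproliferative activity against U-87 MG (Homo sapiens), read by MTT assay, with a stated time of 48 h, tested at 50 uM; on this read-out higher numbers stand for a weaker effect at the one concentration tested and lower numbers for a stronger effect. Compound 1 `COc1ccc(-c2nc(C)c(C(=O)CSc3nc(N)c(C#N)c(-c4ccccc4)n3)s2)cc1` gives 16.5%. Compound 2 `Cc1nc(-c2ccccc2)sc1C(=O)CSc1nc(N)c(C#N)c(-c2ccc(Cl)cc2)n1` gives 44.3%. Compound 3 `Cc1nc(-c2ccc(Cl)cc2)sc1C(=O)CSc1nc(N)c(C#N)c(-c2ccc(Cl)cc2)n1` gives 15.5%, the lowest of the three numbers; compound 1 stands within the scatter of it, while compound 2 lies beyond the scatter above it. For the measured compounds named here, the one measured step is a number 28.8 percentage points lower from compound 2 to compound 3 (beyond the scatter), a chloro entering one of the two phenyl rings of the shared core.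

Compound 4 `Cc1nc(-c2ccc(Cl)cc2)sc1C(=O)CSc1nc(N)c(C#N)c(-c2ccccc2)n1` is not yet measured. It differs from compound 3 in one place: hydrogen in place of chloro on an aromatic carbon. Going by the values given here, the chloro that leaves sits on the phenyl ring that was not changed in the step between compound 2 and compound 3, so no measured step covers exactly this change. Among the compounds with values here, the only step available runs the other way, with a chloro entering, and lowered the number by a modest amount; read in reverse and carried to a different ring, it suggests a number somewhat higher than that of compound 3, but of uncertain size. Compound 1, which also carries plain phenyl at this place, gives a number within the scatter of compound 3, though it differs at the other ring as well.

Compound 4 is therefore expected at 28%, within 12% to 48%, an estimated step of a number 12.5 percentage points higher from compound 3 to compound 4 (beyond the scatter).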

Compound 4, a percentage reported as activity, at one concentration (the size of the read-out at that concentration, not a potency): 15.2%
The estimate for compound 4 lay 12.8 percentage points above the measured number; low and high end bracket the measured number.
By their numbers in this assay, from the lowest: compounds 4, 3 and 1 (each within the scatter of the next); then compound 2.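

In this assay the change from 4-chlorophenyl to phenyl at this position gives a number 0.3 percentage points lower from compound 3 to compound 4 (within the scatter) so, with the rest of compound 3 held fixed, the chloro here makes no readable difference. For the compounds shown here, the one earlier chloro step, on the other phenyl ring of the shared core, gave a number 28.8 percentage points lower from compound 2 to compound 3 (beyond the scatter) so the same exchange of chloro and hydrogen does not read the same at the two rings. With phenyl at this position, the exchange of methoxy for chloro on that other ring gives a number 1.3 percentage points lower from compound 1 to compound 4 (within the scatter) and the two groups are not separated there either. No measurement at hand bears on why the two rings differ in this way.

As far as these compounds go, whether phenyl and 4-chlorophenyl stay level at this position when the other ring carries plain phenyl remains open, as the comparison rests on a single pair. Also open, from the compounds shown here alone, is what an amine, a carboxylic acid or a longer chain at this place would do, and whether the level readings at one concentration in this assay would hold as potencies.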